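Trading an anilino group for an isopentylamino chain

The compounds below may be only part of what the source reports. "The series", "measured", "known", "first", "only" and "open" are said of these compounds alone.

Compounds measured:
compound 1 `CC(=O)NC[C@H]1CN(c2ccc(OC[C@@H](O)CNc3ccccc3)c(F)c2)C(=O)O1` gives 124000 nM in a physicochemical assay for solubility, read by HPLC; a lower number here means a less soluble compound, a higher number a more soluble compound;
compound 2 `CC(=O)NC[C@H]1CN(c2ccc(OC[C@H](O)CNc3cccnc3)c(F)c2)C(=O)O1` gives 10100000 nM.

Compound 1 has the lowest number of the two measured compounds; the nearest is compound 2, reached by an 81-fold higher number from compound 1 to compound 2 (1.91 log units; beyond the scatter), a large step.

Compound 3 `CC(=O)NC[C@H]1CN(c2ccc(OC[C@H](O)CNCCC(C)C)c(F)c2)C(=O)O1` has not been measured. It differs from compound 1 by 1-hydroxy-2-(isopentylamino)ethyl in place of 2-anilino-1-hydroxyethyl on a saturated chain carbon bound to an oxygen on an aromatic ring. Where compound 1 carries a six-membered aromatic ring of carbon only, compound 3 carries no ring at all.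

Among the measured compounds shown here, only one measured step bears on this change: an 81-fold higher number from compound 1 to compound 2 (1.91 log units; beyond the scatter), where the same group on the same place was altered. For the measured compounds named here, that step rose sharply, so a rise is expected here too, though the change in compound 3 goes further than the one in compound 2, and its size is uncertain. For compound 3 the expected step is a 24-fold higher number from compound 1 to compound 3 (1.38 log units; beyond the scatter). Compound 3 is estimated at 3000000 nM, within a range from 400000 nM to 20000000 nM.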

Compound 3, solubility: 7280000 nM
Beside the measured number, compound 3's estimate is 2.4-fold (0.39 log units) below it, and the stated range covers the measured number.
By their numbers in this assay, from the lowest: compound 1; then compounds 3 and 2 (each within the scatter of the next).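

In this assay, a large rise at this position does not need a ring nitrogen: placing 1-hydroxy-2-(isopentylamino)ethyl where 2-anilino-1-hydroxyethyl stood gives a 59-fold higher number from compound 1 to compound 3 (1.77 log units; beyond the scatter), even though the new group has no ring at all. Two very different groups on the amine nitrogen also read alike, since isopentyl in place of pyridin-3-yl gives a 1.4-fold lower number from compound 2 to compound 3 (0.14 log units; within the scatter), leaving compound 2 and compound 3 within the usual scatter of each other. Nothing measured here explains why either replacement departs so far from compound 1.

From the compounds shown here alone, it remains open whether a cyclohexyl ring, a shorter chain such as ethyl or a chain ending in a carboxylic acid on that nitrogen would read like compound 3 or like compound 1. A phenyl ring carrying a methoxy group would also test how far the result for compound 1 extends to other carbon-only aromatic rings.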